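The compounds below may be only part of what the source reports. "The series", "measured", "known", "first", "only" and "open" are said of these compounds alone.

The compounds measured so far in a functional assay on DU-145 cells (Homo sapiens) for cytotoxicity, read by MTT assay (a lower number here means a stronger inhibitor, a higher number a weaker inhibitor), are:
compound 1 `CC(C)=CC[C@@H](OC[C@H](C)O)C1=CC(=O)c2c(O)ccc(O)c2C1=O` with 24500 nM
compound 2 `COCCO[C@H](CC=C(C)C)C1=CC(=O)c2c(O)ccc(O)c2C1=O` with 43200 nM
compound 3 `CC(C)=CC[C@@H](OC(=O)C1CCOC1)C1=CC(=O)c2c(O)ccc(O)c2C1=O` with 47500 nM

Compound 3 gives the highest of the three numbers in this assay, but its nearest neighbour is compound 2, with a 1.1-fold higher number from compound 2 to compound 3 (0.04 log units; within the scatter), and even the gap to compound 1, a 1.9-fold higher number from compound 1 to compound 3 (0.29 log units; within the scatter), stays within the scatter; the three values therefore cannot be ranked against one another. Compound 4 `CCC(CO[C@H](CC=C(C)C)C1=CC(=O)c2c(O)ccc(O)c2C1=O)OC` has not yet been measured. It differs from compound 3 in one place: 2-methoxybutyl in place of (oxolan-3-yl)carbonyl on an oxygen on a saturated carbon. For the measured compounds named here, two measured steps bear on this change. The step of a 1.1-fold higher number from compound 2 to compound 3 (0.04 log units; within the scatter) runs in the opposite direction, from a 2-methoxyethyl ether to the (oxolan-3-yl)carbonyl ester, and was within the scatter. The step of a 1.8-fold higher number from compound 1 to compound 2 (0.25 log units; within the scatter) swaps one chain on that oxygen for another and was also within the scatter. Nothing among the three compounds suggests that exchanging the ring-bearing ester for the 2-methoxybutyl chain should move the number beyond the scatter in either direction. Compound 4 is therefore expected to land close to compounds 2 and 3, with an expected step of a 1.3-fold lower number from compound 3 to compound 4 (0.10 log units; within the scatter). The estimate for compound 4 in this assay is 38000 nM, expected to fall between 14000 nM and 100000 nM.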

Compound 4, half-maximal inhibitory concentration: 45700 nM
Beside the measured number, compound 4's estimate is 1.2-fold (0.08 log units) below it; the range from low to high includes it.
By their numbers in this assay, from the lowest: compounds 1, 2, 4 and 3 (each within the scatter of the next).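

In this assay, putting 2-methoxybutyl in place of (oxolan-3-yl)carbonyl on this oxygen removes the five-membered ring and the double bond outside aromatic rings, yet the step stays within the scatter (a 1.0-fold lower number from compound 3 to compound 4 (0.02 log units; within the scatter)), so the ring-bearing ester and the open-chain ether cannot be told apart here. Extending the ether also leaves the number within the scatter, both for ethyl in place of hydrogen on the chain (a 1.1-fold higher number from compound 2 to compound 4 (0.02 log units; within the scatter)) and for 1-methoxypropyl in place of 1-hydroxyethyl (a 1.9-fold higher number from compound 1 to compound 4 (0.27 log units; within the scatter)), the widest of these three steps. All four compounds therefore sit within the scatter on every listed step, which extends the flat picture to a branched chain, and no evidence is available that would account for this.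

The compounds shown leave open whether an amine or a carboxylic acid at the end of the chain on this oxygen would move the number beyond the scatter. They also leave open whether a much longer chain, such as decyl, or a benzoyl group in that place would do so.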